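The source may hold more compounds than are shown below. What is called first, only, known or untested is meant among the compounds shown, and "the series" means these compounds.

Compounds measured in a functional assay on HCT-116 cells (Homo sapiens) for antiproliferative activity, read by MTT assay, with a stated time of 72 h; a lower number here means a stronger inhibitor, a higher number a weaker inhibitor:
- compound 1 `Cc1ccc(S(=O)(=O)N(C)c2ccc3[nH]c(-c4n[nH]c5ccccc45)cc3n2)cc1` gives 13300 nM
- compound 2 `CN(c1ccc2[nH]c(-c3n[nH]c4ccccc34)cc2n1)S(=O)(=O)c1ccc(Cl)cc1` gives 5980 nM
- compound 3 `COc1ccc(OC)c(S(=O)(=O)N(C)c2ccc3[nH]c(-c4n[nH]c5ccccc45)cc3n2)c1` gives 8400 nM

Compound 3 stands second highest of the three numbers. Its nearest neighbour is compound 2, the step being a 1.4-fold higher number from compound 2 to compound 3 (0.15 log units; within the scatter); its furthest is compound 1, with a 1.6-fold lower number from compound 1 to compound 3 (0.20 log units; within the scatter). Both are within the scatter.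

Compound 4 `CN(c1ccc2[nH]c(-c3n[nH]c4ccccc34)cc2n1)S(=O)(=O)c1cccc([N+](=O)[O-])c1` arises by 3-nitrophenyl in place of 2,5-dimethoxyphenyl on a sulfonyl sulfur. Going by the values given here, the steps that bear on it are the two swaps of the aryl group on the sulfonyl sulfur, a 1.6-fold lower number from compound 1 to compound 3 (0.20 log units; within the scatter) and a 1.4-fold higher number from compound 2 to compound 3 (0.15 log units; within the scatter), neither beyond the scatter; the only step beyond it, a 2.2-fold lower number from compound 1 to compound 2 (0.35 log units; beyond the scatter), is a single substituent exchange on that ring and is modest. Among the compounds with values here, no measured compound carries a nitro group. The step from compound 3 to compound 4 is therefore expected to be small, a 1.1-fold lower number from compound 3 to compound 4 (0.05 log units; within the scatter), with no clear direction. Compound 4 is estimated at 7500 nM, ranging from 3000 nM to 20000 nM.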

Compound 4, half-maximal inhibitory concentration: 13600 nM
For compound 4 the middle estimate is 1.8-fold (0.26 log units) below the measured one, within the range that was stated.
By their numbers in this assay, from the lowest: compounds 2, 3, 1 and 4 (each within the scatter of the next, the first and the last beyond it).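

On the sulfonyl sulfur in this assay, 3-nitrophenyl gives a second aryl group that separates from 4-chlorophenyl (a 2.3-fold higher number from compound 2 to compound 4 (0.36 log units; beyond the scatter)), yet it cannot be told apart from 2,5-dimethoxyphenyl (a 1.6-fold higher number from compound 3 to compound 4 (0.21 log units; within the scatter)) or from 4-methylphenyl (a 1.0-fold higher number from compound 1 to compound 4 (0.01 log units; within the scatter)). Compound 2 therefore differs beyond the scatter only from compound 1 and compound 4, and compound 3 from none. Nothing at hand accounts for these steps.

Still open, as far as these compounds go, is how an aminophenyl group, a carboxyphenyl group or a longer alkyl chain on the sulfonyl sulfur would read in this assay.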